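The source may hold more compounds than are shown below. What is called first, only, known or untested is meant among the compounds shown, and "the series" means these compounds.

In a physicochemical assay for lipophilicity, read by HPLC, in phosphate buffer, measured as chromatographic lipophilicity, at pH 7.4 (a lower number here means a more polar compound, a higher number a more lipophilic compound), three compounds that share a core and differ only in the group on the amide-type nitrogen have been measured. Compound 1 `COc1ccc2nc(C)cc(OCC(=O)Nc3cccc(C)c3)c2c1` gives 4.83, compound 2 `COc1ccc2nc(C)cc(OCC(=O)Nc3cc(F)cc(F)c3)c2c1` gives 5.13, and compound 3 `COc1ccc2nc(C)cc(OCC(=O)Nc3ccc(Cl)c(OC)c3)c2c1` gives 5.09. The three numbers lie within the scatter of one another: the step is a number 0.30 log units higher from compound 1 to compound 2 (within the scatter), then a number 0.26 log units higher from compound 1 to compound 3 (within the scatter), and a number 0.04 log units lower from compound 2 to compound 3 (within the scatter). Compound 3 therefore stands among close neighbours, with no measured separation from either.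

Compound 4 `COc1ccc2nc(C)cc(OCC(=O)NC3CONC3=O)c2c1` differs from compound 3 in a way the measured set does not cover: a group of 6 heavy atoms (3 carbon, 1 nitrogen, 2 oxygen; one five-membered non-aromatic ring with 2 hetero atoms) in place of a group of 9 heavy atoms (7 carbon, 1 oxygen, 1 chlorine; one six-membered aromatic ring of carbon only), on an amide-type nitrogen. Each measured step swaps one substituted phenyl for another and stays within the scatter, so those steps say little about an exchange of an aromatic ring for a small ring carrying a hydrogen-bond donor. A step well beyond the scatter, downward, is expected for compound 4 in this assay, namely a number 2.49 log units lower from compound 3 to compound 4 (beyond the scatter). The estimate for compound 4 is 2.6, with a range from 1.9 to 3.3.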

Compound 4, distribution coefficient: 0.79
Compound 4: the middle estimate sits 1.81 log units above what was measured, and the stated range ends above it.
By their numbers in this assay, from the lowest: compound 4; then compounds 1, 3 and 2 (each within the scatter of the next).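

In this assay this position on the amide-type nitrogen proves highly sensitive to the group it carries, which the substituted phenyl groups could not reveal, as they all stayed within the scatter of one another. The step is large whichever phenyl group leaves, with a number 4.30 log units lower from compound 3 to compound 4 (beyond the scatter) and a number 4.34 log units lower from compound 2 to compound 4 (beyond the scatter) and also a number 4.04 log units lower from compound 1 to compound 4 (beyond the scatter) so the choice among these three phenyl groups makes little difference to the outcome. Nothing available here accounts for the size of this drop.

Among the compounds shown here, only one non-aromatic group stands against the phenyl groups, so it remains open which part of the exchange carries the drop: the loss of the aromatic ring or the hetero atoms of the new ring. A plain cyclopentyl group, a ring with no hetero atoms, could land near the phenyl compounds or near compound 4.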